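Adding a Methoxy Group to Compound 2

The source may report more compounds than this note shows. Statements on the series, on what has been measured and on what is new or still open speak of the compounds shown alone.

Compound 2 (`COc1ccccc1/C=C/C(=O)c1ccc(N)cc1`) is tested in a functional assay on FM3A cells (Mus musculus) for antiproliferative activity, with a stated time of 48 h (on this read-out higher numbers stand for weaker inhibition and lower numbers for stronger inhibition), where compound 2 gives 25000 nM. Compound 1 (`C=C(Br)C(=O)Nc1ccc(C(=O)/C=C/c2ccc(OC)cc2OC)cc1`) gives 1200 nM in this assay. Compound 2 therefore holds the higher of the two numbers, meaning weaker inhibition, and the gap lies beyond the scatter.

The next molecule, compound 3 (`COc1ccc(/C=C/C(=O)c2ccc(N)cc2)c(OC)c1`), has methoxy in place of hydrogen on an aromatic carbon of compound 2: methoxy in place of hydrogen on an aromatic carbon. The new group sits meta to a methoxy group and para to a large group.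

Within the data shown here, no measured pair isolates this change, since compound 1 at 1200 nM differs from compound 2 in more than one place. Only a small shift towards a lower number is therefore expected, probably within the scatter, and the estimated step is a 1.7-fold lower number from compound 2 to compound 3 (0.22 log units; within the scatter). Compound 3 is expected to give 15000 nM, with an estimated range of 5000 nM to 45000 nM.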

Compound 3, half-maximal inhibitory concentration: 43000 nM
Compound 3: middle estimate off by 2.9-fold (0.46 log units), on the low side; the measured number falls inside the stated range.
By their numbers in this assay, from the lowest: compound 1; then compounds 2 and 3 (each within the scatter of the next).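

In this assay, methoxy in place of hydrogen on this aromatic carbon, meta to a methoxy group and para to a large group, gives a 1.7-fold higher number from compound 2 to compound 3 (0.24 log units; within the scatter) and so brings no change beyond the scatter at this position. Compound 3 also allows the first comparison with compound 1 that differs in one place: hydrogen in place of (1-bromoethenyl)carbonyl on the nitrogen gives a 36-fold higher number from compound 1 to compound 3 (1.55 log units; beyond the scatter) and shows that, among these compounds, the group on the nitrogen counts for far more than this methoxy. Nothing shown here explains either step.

On these data alone, it remains open whether a different group on this aromatic carbon, such as hydroxyl or fluorine, would move the number beyond the scatter. As far as these compounds go, it is equally open how much of the (1-bromoethenyl)carbonyl group is needed, for instance whether a plain acetyl on the nitrogen would do as well.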